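Series notes: replacing the six-membered ring on the chain carbon

The compounds below may be only part of what the source reports. "The series", "measured", "known", "first", "only" and "open" are said of these compounds alone.

Measured so far:
- compound 1, `CC(C)C(c1ccc(-c2ccc3cccc(F)c3c2)[nH]c1=O)N1CCCCS1(=O)=O`: 0.07 h
- compound 2, `CC(C)C(c1noc(=O)[nH]1)c1ccc(-c2ccc3cccc(F)c3c2)[nH]c1=O`: > 3 h

Among the measured compounds shown here, in an ADME assay on microsomes from liver (Rattus norvegicus) for metabolic stability (a lower number here means that the compound disappears faster, a higher number that the compound lasts longer), compound 1 gives 0.07 h, the only plain number in the set. Compound 2 sits at a limit of the assay, > 3 h, so the limit of > 3 h in this assay, at which 1 of the 2 values shown sits, rather than a number. For the measured compounds named here, the one measured step, an at least 42-fold higher number from compound 1 to compound 2 (1.63 log units; beyond the scatter), shows that exchanging the group on the saturated chain carbon bound to an aromatic carbon and a saturated chain carbon can move this assay a long way upward.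

Compound 3, `CC(C)C(/C=C1/CCNC1=O)c1ccc(-c2ccc3cccc(F)c3c2)[nH]c1=O`, is not yet measured. Its change from compound 1 is a group of 7 heavy atoms (5 carbon, 1 nitrogen, 1 oxygen; one five-membered non-aromatic ring with 1 hetero atom) in place of a group of 8 heavy atoms (4 carbon, 1 nitrogen, 2 oxygen, 1 sulfur; one six-membered non-aromatic ring with 2 hetero atoms), on a saturated chain carbon bound to an aromatic carbon and a saturated chain carbon. The entering group is a five-membered non-aromatic ring with 1 hetero atom, not the aromatic ring of compound 2, so the measured step is only a loose guide. Because compound 1 gives 0.07 h and the step of an at least 42-fold higher number from compound 1 to compound 2 (1.63 log units; beyond the scatter) was large, a rise is expected, though a smaller one. The step expected here is a 4.3-fold higher number from compound 1 to compound 3 (0.63 log units; beyond the scatter). Compound 3 is estimated at 0.3 h, within 0.07 h to 1.5 h.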

Compound 3, half-life: 0.06 h
Beside the measured number, compound 3's estimate is 5.0-fold (0.70 log units) above it; the whole stated range lies above it.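

In this assay, the exchange of the six-membered non-aromatic ring with 2 hetero atoms for the five-membered non-aromatic ring with 1 hetero atom gives a 1.2-fold lower number from compound 1 to compound 3 (0.07 log units; within the scatter), so these two groups are not told apart at this saturated chain carbon. Among the compounds shown here, a five-membered ring alone therefore does not account for the earlier gain, and the step of an at least 50-fold lower number from compound 2 to compound 3 (1.69 log units; beyond the scatter) leaves compound 2, with its five-membered aromatic ring with 3 hetero atoms, as the one compound set apart from the other two. Compound 2 stands at a limit of the assay and not at a number: the limit of > 3 h in this assay, at which 1 of the 3 values shown sits.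

On these data alone, what remains open is whether the aromatic ring itself or its particular hetero atoms go with the higher number. A carboxylic acid, an amine or a simple pyrazole on the same chain carbon would bear on that question.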